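This account rests on a few compounds, and the source may have more. Where it says the series, first, only, none or still open, it means among the compounds named here.

Measured in an ADME assay on 2209-23 cells (Homo sapiens) for cytotoxicity, read by WST assay; on this read-out lower numbers stand for higher toxicity in this test and higher numbers for lower toxicity in this test:
Compound 1 `O=c1c(C2=CS(=O)(=O)c3cc(F)ccc3N2)c(O)c2cc(F)ccc2n1Cc1ccc(F)cc1`: > 50000 nM
Compound 2 `NC(=O)COc1ccc2c(c1)S(=O)(=O)C=C(c1c(O)c3cc(F)ccc3n(Cc3ccc(F)cc3)c1=O)N2`: > 50000 nM
Compound 3 `Cc1cc(Cn2c(=O)c(C3=CS(=O)(=O)c4cc(NS(C)(=O)=O)ccc4N3)c(O)c3cc(F)ccc32)ccc1F`: > 50000 nM

Compound 3 gives > 50000 nM as its reading, a limit of the assay and not a number. The whole picture so far is the limit of > 50000 nM in this assay, at which 3 of the 3 values shown sit, and so none of the compounds can be ranked.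

Compound 4 `COC(C)(C)CCn1c(=O)c(C2=CS(=O)(=O)c3cc(NS(C)(=O)=O)ccc3N2)c(O)c2cc(F)ccc21` has not been measured yet. Its change from compound 3 is 2-methoxy-2-methylpropyl in place of 4-fluoro-3-methylphenyl on a saturated chain carbon bound to an aromatic nitrogen and, cut one bond further out, it reads 4-fluoro-3-methylbenzyl to 3-methoxy-3-methylbutyl. Within the data shown here, the one measured step, a step that the two limits leave unreadable from compound 1 to compound 2 (carbamoylmethoxy in place of fluoro on an aromatic carbon), is a different change and gives no size to carry over.

That leaves only the limit as a guide. In this assay no step beyond the usual scatter is expected in either direction, and the estimated step is a number no higher from compound 3 to compound 4 (the limit leaves the size open) for now. For compound 4 the estimated value is 50000 nM with an expected range of 20000 nM to 100000 nM and quite possibly only a limit again.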

Compound 4, half-maximal cytotoxic concentration: > 50000 nM
Compound 4 was reported as a limit (the forecaster's own chance of this, stated with the estimate: 85%); the middle value lies on the limit itself.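

No step can be read from compound 3 to compound 4, since both readings are limits and not numbers: the limit of > 50000 nM in this assay, at which 4 of the 4 values shown sit. The compounds shown leave open how far past that limit each one lies, and whether any of them differs from the others in this assay.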